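Nitro for Trifluoromethyl: A Small Shift Expected

The source may report more compounds than this note shows. Statements on the series, on what has been measured and on what is new or still open speak of the compounds shown alone.

Of the compounds shown here, three sharing one core have been tested in a functional assay on PC-3 cells (Homo sapiens) for cytotoxicity, read by MTT assay, with a stated time of 72 h; on this read-out higher numbers stand for weaker inhibition and lower numbers for stronger inhibition. Compound 1 `FC(F)(F)c1ccc(CSc2nc(N3CCCCC3)c3ccccc3n2)cc1` gives 25500 nM. Compound 2 `FC(F)(F)c1ccc(CSc2nc(Nc3ccccc3C(F)(F)F)c3ccccc3n2)cc1` gives 34800 nM, and compound 3 `FC(F)(F)c1ccc(CSc2nc(Nc3cccc(C(F)(F)F)c3)c3ccccc3n2)cc1` gives 12900 nM. Compound 3 holds the lowest of the three numbers, though only narrowly: the step of a 2.0-fold lower number from compound 1 to compound 3 (0.30 log units; within the scatter) stays within the scatter, the step of a 2.7-fold lower number from compound 2 to compound 3 (0.43 log units; beyond the scatter) is modest, and the step of a 1.4-fold higher number from compound 1 to compound 2 (0.14 log units; within the scatter) is within the scatter as well.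

Compound 4 `O=[N+]([O-])c1cccc(Nc2nc(SCc3ccc(C(F)(F)F)cc3)nc3ccccc23)c1` differs from compound 3 by a single change: nitro in place of trifluoromethyl on an aromatic carbon. Among the compounds with values here, none of the measured steps covers this exchange; they either replace the whole group on the shared core or move trifluoromethyl from 2-(trifluoromethyl)phenyl to 3-(trifluoromethyl)phenyl, and all of them remained small. With nothing in the data pointing strongly in either direction, for compound 4 the expected step is a 1.1-fold lower number from compound 3 to compound 4 (0.03 log units; within the scatter), within the scatter. The estimate for compound 4 in this assay is therefore 12000 nM, with a range from 4000 nM to 36000 nM.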

Compound 4, half-maximal inhibitory concentration: 13500 nM
The estimate for compound 4 lay 1.1-fold (0.05 log units) below the measured number, and the stated range covers the measured number.
By their numbers in this assay, from the lowest: compounds 3, 4, 1 and 2 (each within the scatter of the next, the first and the last beyond it).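

Nitro and trifluoromethyl, two groups with different atoms and different counts of hydrogen-bond acceptors, cannot be told apart at this place on the aromatic ring in this assay, where the exchange gives a 1.0-fold higher number from compound 3 to compound 4 (0.02 log units; within the scatter) and so extends what the earlier compounds showed only for trifluoromethyl. The (3-nitrophenyl)amino group also sits where (3-(trifluoromethyl)phenyl)amino sat relative to the other two compounds, with a 2.6-fold lower number from compound 2 to compound 4 (0.41 log units; beyond the scatter) and with a 1.9-fold lower number from compound 1 to compound 4 (0.28 log units; within the scatter), so only the first of these two steps goes beyond the scatter. No measurement at hand explains why the two groups read alike.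

Still open, going by these compounds, is whether an amine or a carboxylic acid at this place would read the same as nitro. The compounds shown also leave open what happens when the trifluoromethyl shared by all four compounds is exchanged for a nitro or a nitrile.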